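A few compounds are considered here, and "the series" means these few. Any claim that something is new, unique, unknown or untested is made for them only; others in the source may bear on it.

The measured compounds:

compound 1, `C=CC(=O)Nc1cccc(NC(=O)CSc2nc(Nc3ccccc3F)c3ccccc3n2)c1`
compound 2, `C=CC(=O)Nc1cccc(NC(=O)CSc2nc(Nc3cccc([N+](=O)[O-])c3)c3ccccc3n2)c1`
compound 3, `C=CC(=O)Nc1cccc(NC(=O)CSc2nc(Nc3cccc(C)c3)c3ccccc3n2)c1`

All three share one core and differ only in the aryl group carried on a nitrogen on an aromatic ring. In a functional assay on MGC-803 cells (Homo sapiens) for inhibition, read by MTT assay, with a stated time of 72 h (a higher number here means a weaker inhibitor, a lower number a stronger inhibitor), compound 1 gives 26100 nM and compound 3 gives 20900 nM. For compound 2 this assay reports only > 50000 nM, which is a limit of the assay and not a number (the limit of > 50000 nM in this assay, at which 1 of the 3 values shown sits). Compound 3 and compound 1 cannot be told apart: a 1.2-fold lower number from compound 1 to compound 3 (0.10 log units; within the scatter). Compound 3 does stand apart from compound 2: an at least 2.3-fold lower number from compound 2 to compound 3 (0.37 log units; beyond the scatter).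

Compound 4, `C=CC(=O)Nc1cccc(NC(=O)CSc2nc(Nc3ccc(F)c(Cl)c3)c3ccccc3n2)c1`, is not yet measured in this assay. It differs from compound 3 by 3-chloro-4-fluorophenyl in place of 3-methylphenyl on a nitrogen on an aromatic ring. The two measured steps touch the same place on the core. One stayed within the scatter, the other was beyond it, and neither carries a 3-chloro-4-fluorophenyl, so the expectation rests mainly on the narrow spread between compound 1 and compound 3. Compound 4 is therefore expected to show a 1.1-fold higher number from compound 3 to compound 4 (0.02 log units; within the scatter), a step not clearly beyond the scatter. The estimate for compound 4 in this assay is 22000 nM, with a range from 9000 nM to 50000 nM.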

Compound 4, half-maximal inhibitory concentration: 7850 nM
Estimate against measurement, compound 4: 2.8-fold (0.45 log units) above; the whole stated range lies above it.
By their numbers in this assay, from the lowest: compound 4; then compounds 3 and 1 (each within the scatter of the next). At a limit, above all of these: compound 2.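

Up to this point, the aryl group on this nitrogen had separated only compound 2 from the others, while compound 1 and compound 3 could not be told apart in this assay. Compound 4 now stands clear of both, with a 2.7-fold lower number from compound 3 to compound 4 (0.43 log units; beyond the scatter) and a 3.3-fold lower number from compound 1 to compound 4 (0.52 log units; beyond the scatter), so a change at this position can lower the number as well as leave it unmoved, and the 3-chloro-4-fluorophenyl group gives the lowest number of the four, with an at least 6.3-fold lower number from compound 2 to compound 4 (0.80 log units; beyond the scatter) as its widest step. Compound 2 has only a limit and not a number: the limit of > 50000 nM in this assay, at which 1 of the 4 values shown sits.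

The compounds shown do not separate the chlorine from the fluorine: neither a 3-chlorophenyl nor a 4-fluorophenyl group on this nitrogen is among them, so it stays open whether one of the two atoms alone would give the same number or whether both are needed. On these data alone, it is also open how the number would respond to a methoxy group, a carboxylic acid or an amine on this aryl ring.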